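A few compounds are considered here, and "the series" means these few. Any claim that something is new, unique, unknown or untested is made for them only; others in the source may bear on it.

Compound 3 `O=C(COc1ccc2c(=O)ccoc2c1)Nc1cccc(NC(=O)c2ccc(Br)cc2)c1` gives 49 nM in an assay on isolated protein for inhibition of Rho-associated protein kinase 2 (Homo sapiens), read by scintillation counting, radiometric assay and 33P incorporation, with a stated time of 40 min, in the presence of a further agent that is not named here (a lower number here means a stronger inhibitor, a higher number a weaker inhibitor), the lowest of the two numbers measured here. Compound 1 `COc1ccc(OCC(=O)Nc2cccc(NC(=O)c3ccc(N(C)C)cc3)c2)cc1F` gives 652 nM in this assay. Compound 2 `CN(C)c1ccc(C(=O)Nc2cccc(NC(=O)COc3ccc4occc(=O)c4c3)c2)cc1` reaches only a limit in this assay, > 10000 nM, which is a limit and not a number (the limit of > 10000 nM in this assay, at which 1 of the 3 values shown sits). Going by the values given here, the only measured step, an at least 15-fold higher number from compound 1 to compound 2 (1.18 log units; beyond the scatter), alters the group on the ether oxygen, not the amide side. Compound 4 `CC(C)(C)c1cc(C(=O)Nc2cccc(NC(=O)COc3ccc4c(=O)ccoc4c3)c2)no1` has not yet been measured. (5-(tert-butyl)-1,2-oxazol-3-yl in place of 4-bromophenyl on a carbonyl carbon). No measured step touches this position, so the numbers shown give no guide to its size. A modest step toward a weaker inhibitor is expected, a 3.1-fold higher number from compound 3 to compound 4 (0.49 log units; beyond the scatter). Compound 4 is estimated at 150 nM, within a range from 30 nM to 800 nM.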

Compound 4, half-maximal inhibitory concentration: 5 nM
Compound 4: middle estimate off by 30-fold (1.48 log units), on the high side, outside the stated range (below it).
By their numbers in this assay, from the lowest: compound 4; then compound 3; then compound 1. At a limit, above all of these: compound 2.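

Going by these compounds alone, the group on the carbonyl carbon, which no earlier step touched, proves to have a strong hold on the number in this assay: 5-(tert-butyl)-1,2-oxazol-3-yl in place of 4-bromophenyl gives a 9.8-fold lower number from compound 3 to compound 4 (0.99 log units; beyond the scatter). The six-membered carbon ring is therefore not needed here, since the five-membered aromatic ring of 5-(tert-butyl)-1,2-oxazol-3-yl does better. Nothing shown here explains this gain. As far as these compounds go, whether the tert-butyl or the ring itself carries the gain stays open. A methyl group in place of the tert-butyl, or a tert-butylphenyl group on that carbonyl carbon, would help separate the two.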